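Carbamate replacement of the ethyl ether: compound 4 outlook

The compounds below may be only part of what the source reports. "The series", "measured", "known", "first", "only" and "open" are said of these compounds alone.

Measured so far:
- compound 1 `CCOc1cc(=O)n(CCCO)c2c1CC(CC=C(C)C)C(C)(C)C2`: 16.6%
- compound 2 `CC(C)=CCC1Cc2c(OCCCNC(=O)c3cccs3)cc(=O)n(CCCO)c2CC1(C)C`: 5.6%
- compound 3 `COc1ccccc1NC(=O)Oc1cc(=O)n(CCCO)c2c1CC(CC=C(C)C)C(C)(C)C2`: 0%

In a functional assay on PANC-1 cells (Homo sapiens) for inhibition, read by MTT assay, with a stated time of 24 h, tested at 10 uM (a lower number here means less inhibition, a higher number more inhibition at the concentration tested (going by the name of the read-out)), compound 1 stands highest of the three numbers, with compound 2 nearest and compound 3 furthest. Compound 4 `CC(C)=CCC1Cc2c(OC(=O)Nc3ccc(Cl)c(Cl)c3)cc(=O)n(CCCO)c2CC1(C)C` is not yet measured; it differs from compound 1 by (3,4-dichlorophenyl)carbamoyl in place of ethyl on an oxygen on an aromatic ring. The step that bears on this change is the replacement of the same ethyl by (2-methoxyphenyl)carbamoyl, which gave a number 16.6 percentage points lower from compound 1 to compound 3 (beyond the scatter). Bearing in mind that compound 3 fell to 0%, compound 4 is expected to lose inhibition in this assay by a step of about a number 13.6 percentage points lower from compound 1 to compound 4 (beyond the scatter). The estimate for compound 4 is 3%, within 0% to 14%.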

Compound 4, a percentage reported as inhibition, at one concentration (the size of the read-out at that concentration, not a potency): 1.8%
Compound 4: middle estimate off by 1.2 percentage points, on the high side, and the stated range covers the measured number.
By their numbers in this assay, from the lowest: compounds 3, 4 and 2 (each within the scatter of the next); then compound 1.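

In this assay, a second phenyl carbamate on the oxygen on an aromatic ring gives a similar loss (a number 14.8 percentage points lower from compound 1 to compound 4 (beyond the scatter)), so the drop is not confined to (2-methoxyphenyl)carbamoyl. Exchanging the phenyl substituents leaves the reading within the scatter (a number 1.8 percentage points higher from compound 3 to compound 4 (within the scatter)), as does exchanging the carbamate for the thiophene amide chain (a number 3.8 percentage points lower from compound 2 to compound 4 (within the scatter)). No measured evidence accounts for these results. Open, going by these compounds, is whether a propyl ether on this oxygen would hold or raise the reading of compound 1. Also open, on these data alone, is how a chain ending in an amine or a carboxylic acid would read here.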